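The source may hold more compounds than are shown below. What is called first, only, known or untested is meant among the compounds shown, and "the series" means these compounds.

Measured compounds:
- compound 1, `CCN(CC)CCN(C)c1ccc(Cn2c(=O)[nH]c3c(N)nc(C(F)(F)F)cc32)cn1`, 1.3
- compound 2, `CN(CCN1CCCCC1)c1ccc(Cn2c(=O)[nH]c3c(N)nc(C(F)(F)F)cc32)cn1`, 1.8
- compound 3, `CN1CCN(CCN(C)c2ccc(Cn3c(=O)[nH]c4c(N)nc(C(F)(F)F)cc43)cn2)CC1`, 1.5

All three share one core and differ only in the group at the end of a short chain. In a physicochemical assay for lipophilicity (a higher number here means a more lipophilic compound, a lower number a more polar compound), compound 1 gives the lowest of the three numbers. Compound 3 stands nearest to it, with a number 0.20 log units higher from compound 1 to compound 3 (within the scatter), and compound 2 furthest, with a number 0.50 log units higher from compound 1 to compound 2 (beyond the scatter). The step from compound 2 to compound 3 is a number 0.30 log units lower from compound 2 to compound 3 (within the scatter).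

Compound 4, `CN(C)CCN(C)c1ccc(Cn2c(=O)[nH]c3c(N)nc(C(F)(F)F)cc32)cn1`, has not yet been measured. It differs from compound 1 in one place: dimethylamino in place of diethylamino on a saturated chain carbon, two bonds along the chain from a nitrogen on an aromatic ring. Both measured steps from compound 1 replace the diethylamino group with a ring, and both move the number upward or leave it within the scatter, so neither is a direct match for this change; a shift to a smaller group with fewer carbon atoms is a new direction here. The expectation for compound 4 in this assay is a downward step, a number 0.60 log units lower from compound 1 to compound 4 (beyond the scatter), and the estimated value is 0.7, between 0.3 and 1.1.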

Compound 4, distribution coefficient: 1.2
Compound 4: the middle estimate sits 0.50 log units below what was measured; the whole stated range lies below it.
By their numbers in this assay, from the lowest: compounds 4, 1, 3 and 2 (each within the scatter of the next, the first and the last beyond it).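

In this assay, replacing diethylamino with dimethylamino, a change between two open-chain groups with no ring on either side, leaves the two compounds within the scatter (a number 0.10 log units lower from compound 1 to compound 4 (within the scatter)), so at this position, on a saturated chain carbon, two bonds along the chain from a nitrogen on an aromatic ring, trimming the open-chain group does not separate them. Dimethylamino also stays within the scatter of the ring group 4-methylpiperazin-1-yl (a number 0.30 log units lower from compound 3 to compound 4 (within the scatter)), whereas the step from piperidin-1-yl is beyond it (a number 0.60 log units lower from compound 2 to compound 4 (beyond the scatter)), which leaves compound 2 clearly apart from both open-chain compounds. Nothing available here accounts for this result.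

As far as these compounds go, whether a pyrrolidin-1-yl or morpholin-4-yl group would stand with compound 2 or with compounds 1, 3 and 4 remains open. So does the outcome of the same amine swaps on a longer chain.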